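The source may report more compounds than this note shows. Statements on the series, on what has been measured and on what is new or still open speak of the compounds shown alone.

In an ADME assay on HEp-2 cells (Homo sapiens) for cytotoxicity (a higher number here means that more compound is tolerated, a lower number that less compound is tolerated), the three measured compounds read:
compound 1 (`CC(C)CCn1c(Cn2c(=O)n(C(C)C)c3ccccc32)nc2cc(CN(C)C)ccc21`) at 5650 nM
compound 2 (`COC(=O)c1cccc2nc(Cn3c(=O)n(C(C)C)c4ccccc43)n(CCC(C)C)c12`) at 25300 nM
compound 3 (`CC(C)CCn1c(Cn2c(=O)n(CC(=O)OC(C)(C)C)c3ccccc32)nc2cc(C#N)ccc21`) at 32200 nM

Compound 1 holds the lowest number of the three, and the numbers of compound 2 and compound 3 both lie above it, beyond the scatter. Of these three, only compound 1 carries a (dimethylamino)methyl. Compound 4 (`C=Cc1ccc2c(c1)nc(Cn1c(=O)n(C(C)C)c3ccccc31)n2CCC(C)C`) gives that group up: vinyl in place of (dimethylamino)methyl on an aromatic carbon. Going by the values given here, no measured pair differs in one place only, so the size of this change in this assay cannot be read directly. Compound 2 (25300 nM) and compound 3 (32200 nM) also lack the (dimethylamino)methyl, but they differ from compound 1 elsewhere too and are only a loose guide. An upward step beyond the scatter is therefore expected, and the estimate is a 3.5-fold higher number from compound 1 to compound 4 (0.55 log units; beyond the scatter) in size. For compound 4 the expected value is 20000 nM (estimated range 8000 nM to 50000 nM).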

Compound 4, half-maximal cytotoxic concentration: 6520 nM
The estimate for compound 4 lay 3.1-fold (0.49 log units) above the measured number; the measured number lies below the stated range.
By their numbers in this assay, from the lowest: compounds 1 and 4 (each within the scatter of the next); then compounds 2 and 3 (each within the scatter of the next).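

Swapping the (dimethylamino)methyl for vinyl on this aromatic carbon gives, in this assay, a 1.2-fold higher number from compound 1 to compound 4 (0.06 log units; within the scatter), the first direct reading of a change at this position. The loss of that group, with its nitrogen, and the arrival of a double bond outside aromatic rings therefore leave the number within the scatter, so the (dimethylamino)methyl alone does not account for the low number of compound 1. No measurement at hand offers an explanation for this result.

Going by these compounds, whether a carboxylic acid or a primary amine on the same aromatic carbon would also stay within the scatter of compound 1 remains open. The steps to compound 2 and compound 3 cannot be read, as each differs from compound 1 and compound 4 in more than one place.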